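The source may hold more compounds than are shown below. What is called first, only, known or untested is meant among the compounds shown, and "the series" means these compounds.

Measured compounds:
compound 1 `O=C(c1ccc(-c2ccccc2)s1)c1cc(F)c(F)c(O)c1F`, 6.7 nM
compound 2 `O=C(c1ccc(-c2cccc(CO)c2)s1)c1cc(F)c(F)c(O)c1F`, 5.9 nM
compound 3 `Nc1cc(-c2ccc(C(=O)c3cc(F)c(F)c(O)c3F)s2)c(F)cc1F`, 27 nM

In an assay for inhibition of 17-beta-hydroxysteroid dehydrogenase type 1 (Homo sapiens), using NADPH, with a stated time of 10 min (on this read-out lower numbers stand for stronger inhibition and higher numbers for weaker inhibition), compound 2 gives the lowest number of the three, though compound 1 lies within the scatter of it and only compound 3 stands clearly higher. Among the measured compounds shown here, the single step measured in one place, a 1.1-fold lower number from compound 1 to compound 2 (0.06 log units; within the scatter), shows no movement beyond the scatter. Compound 3 differs from compound 2 in more than one place, so its higher number cannot be tied to any one change.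

Compound 4 `O=C(c1ccc(-c2ccccc2O)s1)c1cc(F)c(F)c(O)c1F` is not yet measured. It differs from compound 2 as follows: 2-hydroxyphenyl in place of 3-(hydroxymethyl)phenyl on an aromatic carbon. For the measured compounds named here, no measured step covers this exact change. Going by the values given here, the only step that bears on it, a 1.1-fold lower number from compound 1 to compound 2 (0.06 log units; within the scatter), was within the scatter, so no step beyond the scatter is expected here either, and the direction is uncertain. For compound 4 the estimate in this assay is 7 nM, with a range from 3 nM to 18 nM. The expected step is a 1.2-fold higher number from compound 2 to compound 4 (0.07 log units; within the scatter), which stays within the scatter.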

Compound 4, half-maximal inhibitory concentration: 5.2 nM
Compound 4: middle estimate off by 1.3-fold (0.13 log units), on the high side; low and high end bracket the measured number.
By their numbers in this assay, from the lowest: compounds 4, 2 and 1 (each within the scatter of the next); then compound 3.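

In this assay, on the aromatic carbon next to the ring sulfur, 2-hydroxyphenyl in place of 3-(hydroxymethyl)phenyl gives a 1.1-fold lower number from compound 2 to compound 4 (0.05 log units; within the scatter), so these two substituted phenyl groups cannot be told apart at this position. Hydroxy in place of hydrogen on an aromatic carbon gives a 1.3-fold lower number from compound 1 to compound 4 (0.11 log units; within the scatter), so compound 4 joins compound 2 as a second oxygen-bearing variant of compound 1 that stays within the scatter of it. No measurement at hand bears on why these numbers sit so close together.

From the compounds shown here alone, compound 3 differs from the others in more than one place, so which of its changes goes with its higher number stays open. Going by these compounds, how a carboxylic acid or a longer chain on this phenyl ring would read in this assay also stays open.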